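Isopropyl for methyl on the lactone ring of compound 2

This account rests on a few compounds, and the source may have more. Where it says the series, first, only, none or still open, it means among the compounds named here.

Measured compounds: compound 2 `CC(=O)O[C@@H]1OC(=O)[C@@](C)(C(C)=O)[C@@H]1C` gives 12000 nM in a functional assay on HT-29 cells (Homo sapiens) for cytotoxicity, read by MTT assay; on this read-out lower numbers stand for stronger inhibition and higher numbers for weaker inhibition. Compound 3 `CC(=O)[C@]1(C)C(=O)O[C@@H](OC(=O)c2ccccc2)[C@H]1C` gives 6000 nM in this assay. Compound 1 `CC(=O)O[C@@H]1OC(=O)[C@](C)(C(C)=O)[C@@H]1C(C)C` reaches only a limit of the assay in this assay, > 50000 nM.

Compound 2 has the highest of the two numbers, with compound 3 nearest after a step of a 2.0-fold lower number from compound 2 to compound 3 (0.30 log units; within the scatter). Compound 4 `CC(=O)O[C@@H]1OC(=O)[C@@](C)(C(C)=O)[C@@H]1C(C)C` differs from compound 2 by isopropyl in place of methyl on a saturated ring carbon. Going by the values given here, no measured step touches this position; the only measured step, from compound 2 to compound 3, changes a group on a carbonyl carbon and stays within the scatter. Compound 4 is therefore expected to sit close to compound 2, with a step of a 1.5-fold higher number from compound 2 to compound 4 (0.18 log units; within the scatter), at an estimated 18000 nM between 7000 nM and 50000 nM.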

Compound 4, half-maximal inhibitory concentration: > 50000 nM
Compound 4: a limit, no number (the forecaster's own chance of this, stated with the estimate: 30%); middle value at least 2.7-fold (0.44 log units) away from the limit.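

Isopropyl in place of methyl on this saturated ring carbon gives the only step in this assay that lies beyond the scatter: an at least 4.1-fold higher number from compound 2 to compound 4 (0.61 log units; beyond the scatter). Compound 4 gives a limit of the assay and not a number, so the full size of this step stays unknown: the limit of > 50000 nM in this assay, at which 2 of the 4 values shown sit. The step between compound 1 and compound 4 cannot be read, so this pair shows nothing about the configuration at this carbon: the fact that compounds 1 and 4 differ only in the configuration as drawn

Still open, on these data alone, is whether ethyl or hydroxymethyl on this ring carbon would give a number in this assay rather than a limit.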